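Formylamino to Ethylcarbamoylamino on a Shared Oxazolidinone Core

The source may hold more compounds than are shown below. What is called first, only, known or untested is meant among the compounds shown, and "the series" means these compounds.

Measured so far in an ADME assay on L02 cells (Homo sapiens) for cytotoxicity, read by MTT assay, with a stated time of 48 h; on this read-out higher numbers stand for weaker inhibition and lower numbers for stronger inhibition:
compound 1, `O=C1CCC(=O)N1C[C@H]1CN(c2ccc(-n3cc(-c4ccccn4)cn3)c(F)c2)C(=O)O1`, gives > 400 ug/mL, a limit of the assay.
compound 2, `O=CNC[C@H]1CN(c2ccc(-n3cc(-c4ccccn4)cn3)c(F)c2)C(=O)O1`, gives > 400 ug/mL, also a limit of the assay.

Within the data shown here, both values sit at the limit of > 400 ug/mL in this assay, at which 2 of the 2 values shown sit, so the only measured step, a step that the two limits leave unreadable from compound 1 to compound 2, cannot be read as a number in either direction. Compound 2 therefore stands at the limit of this assay, with no numerical value of its own and no measured neighbour that offers one.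

Compound 3, `CCNC(=O)NC[C@H]1CN(c2ccc(-n3cc(-c4ccccn4)cn3)c(F)c2)C(=O)O1`, differs from compound 2 by ethylamino in place of hydrogen on a carbonyl carbon. Among the measured compounds shown here, the one measured step bears on this change only in so far as it shows that exchanging the group on the saturated chain carbon did not bring either compound below the limit; it gives no size to carry over. On that basis compound 3 is expected to remain at the same limit, with the step of a number no higher from compound 2 to compound 3 (the limit leaves the size open) estimated as nothing beyond the scatter. The estimate for compound 3 is 400 ug/mL, between 200 ug/mL and 800 ug/mL, most likely reported again as a limit.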

Compound 3, half-maximal inhibitory concentration: > 400 ug/mL
Compound 3 ended at the assay's limit (the forecaster's own chance of this, stated with the estimate: 85%); the middle value lies on the limit itself.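

In this assay compound 3 gives > 400 ug/mL as a limit of the assay. Among these compounds, no step among compound 1, compound 2 and compound 3 can be read, since all three stand at the same limit: the limit of > 400 ug/mL in this assay, at which 3 of the 3 values shown sit. The compounds shown leave open what numerical value each would have and how far apart the three lie on this read-out.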